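A few compounds are considered here, and "the series" means these few. Any claim that something is new, unique, unknown or untested is made for them only; others in the source may bear on it.

Measured compounds:

Compound 1, `O=C(CSc1nc(Nc2ccccc2)c2ccccc2n1)Nc1cccc(Cl)c1`, gives 12600 nM.
Compound 2, `C=CC(=O)Nc1cccc(NC(=O)CSc2nc(Nc3ccccc3)c3ccccc3n2)c1`, gives 8740 nM.
Compound 3, `O=C(CSc1nc(Nc2ccccc2)c2ccccc2n1)Nc1ccc(F)c(Cl)c1`, gives 15500 nM.

These three numbers come from a functional assay on PC-3 cells (Homo sapiens) for inhibition, read by MTT assay, with a stated time of 72 h; on this read-out higher numbers stand for weaker inhibition and lower numbers for stronger inhibition. All three compounds share one core, and they differ only in the ring on the amide-type nitrogen. Between compound 1 and compound 2 the difference is (vinylcarbonyl)amino in place of chloro on an aromatic carbon, and the step is a 1.4-fold lower number from compound 1 to compound 2 (0.16 log units; within the scatter). Between compound 1 and compound 3 the difference is fluoro in place of hydrogen on an aromatic carbon, with a step of a 1.2-fold higher number from compound 1 to compound 3 (0.09 log units; within the scatter). The remaining pair shows a 1.8-fold higher number from compound 2 to compound 3 (0.25 log units; within the scatter). None of these steps reaches beyond the scatter, so the three compounds cannot be ranked against each other.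

Compound 4, `C=CC(=O)Nc1cccc(NC(=O)CSc2nc(Nc3ccccc3F)c3ccccc3n2)c1`, has not yet been measured. It differs from compound 2 by fluoro in place of hydrogen on an aromatic carbon. This is the same kind of change as that from compound 1 to compound 3, but not the same: there the entering fluoro sat ortho to a chloro group and para to a large group, whereas here it sits ortho to a large group, on the other ring of the molecule. The two cores differ by (vinylcarbonyl)amino in place of chloro on an aromatic carbon. Because the earlier step of the same kind was a 1.2-fold higher number from compound 1 to compound 3 (0.09 log units; within the scatter), the expectation for compound 4 is a step of a 1.1-fold higher number from compound 2 to compound 4 (0.04 log units; within the scatter) in this assay, within the scatter. Compound 4 is thus estimated at 9500 nM, expected to fall between 4500 nM and 20000 nM.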

Compound 4, half-maximal inhibitory concentration: 9340 nM
Beside the measured number, compound 4's estimate is 1.0-fold (0.01 log units) above it; the range from low to high includes it.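

In this assay, turning anilino into (2-fluorophenyl)amino gives a 1.1-fold higher number from compound 2 to compound 4 (0.03 log units; within the scatter), so this fluoro makes no readable difference on the core of compound 2. The same kind of change on the other core tells the same story, and the two steps agree: the same change on two cores in this assay, a 1.2-fold higher number (0.09 log units; within the scatter) from compound 1 to compound 3 and a 1.1-fold higher number (0.03 log units; within the scatter) from compound 2 to compound 4, 1.2-fold (0.06 log units) apart, within the scatter of two such steps. This shows that in both pairs, fluoro in place of hydrogen left the number within the scatter, but it does not show that a real effect of fluoro carries from one core to the other: neither step is large enough to be told from noise, the fluoro sits at a different place in each pair, and two pairs are too few to support a general rule for the series.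

Still open, as far as these compounds go, is whether a different group on the same ring, such as a methoxy group, an amine or a carboxylic acid, would move the number beyond the scatter, which would give a step large enough to test properly on a second core. Also open, from the compounds shown here alone, is whether an acetyl group in place of the vinylcarbonyl group on compound 2 would change the number at all.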